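This account rests on a few compounds, and the source may have more. Where it says the series, first, only, none or still open, it means among the compounds named here.

Compound 1, `CCCNc1ncnc2c1cnn2-c1ccccc1`, gives > 100000 nM in a functional assay on G-361 cells (Homo sapiens) for cytotoxicity, read by sulforhodamine B assay; on this read-out higher numbers stand for weaker inhibition of growth and lower numbers for stronger inhibition of growth.
Compound 2, `CCCNc1nc(C)nc2c1cnn2-c1ccccc1`, gives > 100000 nM in this assay.

The value for compound 1 is a limit of the assay and not a measured number. The value for compound 2 is likewise only a limit. Compound 2 therefore stands at the upper edge of what this assay reports, with no readable number of its own. Within the data shown here, the one measured step, a step that the two limits leave unreadable from compound 1 to compound 2, cannot be sized, since both of its ends rest on a limit; all that is known is that both compounds sit at the limit of > 100000 nM in this assay, at which 2 of the 2 values shown sit.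

Compound 3, `CCCNc1nc(CC)nc2c1cnn2-c1ccccc1`, differs from compound 2 by methyl in place of hydrogen on a saturated chain carbon bound to an aromatic carbon. Among the measured compounds shown here, nothing among the measured compounds gives a direction for this change, and with both neighbours at the limit of > 100000 nM in this assay, at which 2 of the 2 values shown sit, the expectation is that compound 3 stays where compound 2 stands, which means an estimated step that the limit leaves unreadable from compound 2 to compound 3. Compound 3 is therefore estimated at 150000 nM, with a likely range from 30000 nM to 600000 nM, and most probably this assay will again report only a limit.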

Compound 3, concentration for total growth inhibition: 37000 nM
Beside the measured number, compound 3's estimate is 4.1-fold (0.61 log units) above it; measured number inside the range.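

Compound 3 gives this series its first readable number in this assay, which shows that the group on this carbon can shift the read-out towards stronger inhibition of growth. Going from methyl to ethyl here gives an at least 2.7-fold lower number from compound 2 to compound 3 (0.43 log units; beyond the scatter), and ethyl in place of hydrogen on the aromatic carbon gives an at least 2.7-fold lower number from compound 1 to compound 3 (0.43 log units; beyond the scatter); both steps lie beyond the usual scatter, and each could be larger still, since each starts from a limit and not from a measured number. The step between compound 1 and compound 2 cannot be read, so a methyl group alone shows no effect that can be sized, and the earlier compounds marked only the edge of what the assay reports: the limit of > 100000 nM in this assay, at which 2 of the 3 values shown sit.

The compounds shown leave open whether a longer chain, such as propyl or butyl, would push the number lower still or whether the gain ends at ethyl. They also leave open how an amine or a carboxylic acid at this position would read, and a single measured number cannot yet establish a trend.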